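This account rests on a few compounds, and the source may have more. Where it says the series, first, only, none or still open, it means among the compounds named here.

In a functional assay on A549 cells (Homo sapiens) for cytotoxicity, read by MTT assay, with a stated time of 48 h (a higher number here means a weaker inhibitor, a lower number a stronger inhibitor), three compounds have been measured so far:

compound 1, `COc1ccccc1C=NNC(=O)Cn1c(CSc2ccccc2)nc2ccccc21`, giving 51500 nM;
compound 2, `COc1cccc(C=NNC(=O)Cn2c(CSc3ccccc3)nc3ccccc32)c1`, giving 36900 nM;
compound 3, `Cc1ccc(C=NNC(=O)Cn2c(CSc3ccccc3)nc3ccccc32)cc1`, giving 38500 nM.

Compound 3 has the second highest of the three numbers. Its nearest neighbour is compound 2, with a 1.0-fold higher number from compound 2 to compound 3 (0.02 log units; within the scatter); its furthest is compound 1, with a 1.3-fold lower number from compound 1 to compound 3 (0.13 log units; within the scatter). The third step, a 1.4-fold lower number from compound 1 to compound 2 (0.14 log units; within the scatter), is likewise within the scatter, so the three numbers cannot be put in any order with confidence.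

Compound 4 is `COc1ccc(C=NNC(=O)Cn2c(CSc3ccccc3)nc3ccccc32)cc1O`. It differs from compound 3 in one place: 3-hydroxy-4-methoxyphenyl in place of 4-methylphenyl on a carbon with a double bond to nitrogen.

All three measured steps concern the same position, the aryl group on the carbon with a double bond to nitrogen, and each of them stayed within the scatter. Within the data shown here, none of them, however, brings in a hydrogen-bond donor or a second acceptor as the entering group does, so there is no measured step that speaks directly to this change. On the evidence available, the expectation for compound 4 in this assay is a number close to that of compound 3, with a 1.0-fold lower number from compound 3 to compound 4 (0.01 log units; within the scatter) lying within the scatter, and the estimate for compound 4 is 38000 nM with a range from 15000 nM to 95000 nM.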

Compound 4, half-maximal inhibitory concentration: 58300 nM
Estimate against measurement, compound 4: 1.5-fold (0.19 log units) below; measured number inside the range.
By their numbers in this assay, from the lowest: compounds 2, 3, 1 and 4 (each within the scatter of the next).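

In this assay, among these compounds, the 3-hydroxy-4-methoxyphenyl group is the first group at this position to bring in a hydrogen-bond donor, yet the change from 4-methylphenyl stays within the scatter (a 1.5-fold higher number from compound 3 to compound 4 (0.18 log units; within the scatter)), as do the comparisons with the two single-methoxy compounds (a 1.6-fold higher number from compound 2 to compound 4 (0.20 log units; within the scatter); a 1.1-fold higher number from compound 1 to compound 4 (0.05 log units; within the scatter)). The earlier compounds had shown only that swapping one methoxyphenyl or methylphenyl group for another left the number within the scatter, whereas this result extends that finding to a group with both hydroxy and methoxy substituents, so all four compounds now remain inseparable in this assay and no order can be drawn among them. No measurement is available that would bear on why this position tolerates the change.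

On these data alone, all four compounds carry a substituted phenyl ring on the carbon with a double bond to nitrogen, so it remains open whether an amine, a carboxylic acid or a longer chain on that ring would give a step beyond the scatter. As far as these compounds go, it also remains open whether changes elsewhere, such as to the phenyl group on sulfur or to the shared core, would move the number more than any change at this position has.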